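The compounds below may be only part of what the source reports. "The series", "measured", "known", "first", "only" and "open" are said of these compounds alone.

Compound 1 `Cc1cn(C2CC(N=[N+]=[N-])C(COC(=O)CCCN)O2)c(=O)[nH]c1=O` gives 0.433 h. Compound 2 `Cc1cn(C2CC(N=[N+]=[N-])C(COC(=O)OCCO)O2)c(=O)[nH]c1=O` gives only a limit of the assay, < 0.0167 h. Compound 3 `Cc1cn(C2CC(N=[N+]=[N-])C(COC(=O)OCCCCCO)O2)c(=O)[nH]c1=O` gives 0.267 h.

In an ADME assay on the whole organism (serum) with Homo sapiens as the target (a higher number here means that the compound lasts longer, a lower number that the compound disappears faster), compound 3 sits close to compound 1, as the step of a 1.6-fold lower number from compound 1 to compound 3 (0.21 log units; within the scatter) shows; the remaining value, that of compound 2, is a limit of this assay and not a number. Compound 4 `Cc1cn(C2CC(N=[N+]=[N-])C(COC(=O)OCCCN)O2)c(=O)[nH]c1=O` differs from compound 3 by amino in place of 2-hydroxyethyl on a saturated chain carbon, three bonds along the chain from an oxygen next to a carbonyl group. Among the compounds with values here, two measured steps bear on this change. In the step of an at least 15-fold higher number from compound 2 to compound 3 (1.20 log units; beyond the scatter) the hydroxy-bearing chain grew longer and the number rose strongly. In the step of a 1.6-fold lower number from compound 1 to compound 3 (0.21 log units; within the scatter) an amine-bearing chain and a hydroxy-bearing chain gave similar numbers. Compound 4 carries a shorter chain than compound 3 but ends in an amino group, so a moderate fall is expected: a 1.8-fold lower number from compound 3 to compound 4 (0.25 log units; within the scatter). Compound 4 is estimated at 0.15 h, with a range from 0.03 h to 0.5 h.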

Compound 4, half-life: 0.133 h
Estimate against measurement, compound 4: 1.1-fold (0.05 log units) above; low and high end bracket the measured number.
By their numbers in this assay, from the lowest: compounds 4, 3 and 1 (each within the scatter of the next, the first and the last beyond it). At a limit, below all of these: compound 2.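

In this assay, amino in place of 2-hydroxyethyl at this chain carbon stays within the scatter, as the step of a 2.0-fold lower number from compound 3 to compound 4 (0.30 log units; within the scatter) shows. The step of an at least 7.9-fold higher number from compound 2 to compound 4 (0.90 log units; beyond the scatter) starts from a limit of the assay and not a number, so it gives only a minimum size. With the amine end kept, the carbonyl carbon's substituent alone matters beyond the scatter: a 3.3-fold lower number from compound 1 to compound 4 (0.51 log units; beyond the scatter). Still open, from the compounds shown here alone, is how a longer chain ending in an amine would behave, or a chain ending in a carboxylic acid.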